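A few compounds are considered here, and "the series" means these few. Any claim that something is new, unique, unknown or untested is made for them only; others in the source may bear on it.

Measured so far in the series:

compound 1, `CC(C)(C)C1=C(C(=O)O)N2C(=O)[C@H]([C@H](O)c3ccccc3)[C@H]2O1`: 7 h
compound 2, `Cn1cc([C@@H](O)[C@H]2C(=O)N3C(C(=O)O)=C(C(C)(C)C)O[C@H]23)nn1`: 6.8 h
compound 3, `CC(C)(C)C1=C(C(=O)O)N2C(=O)[C@H]([C@H](O)c3ccncc3)[C@H]2O1`: 6.4 h

All three numbers come from an ADME assay, in phosphate buffer, at 28 degrees C, at pH 7.0; a lower number here means that the compound disappears faster, a higher number that the compound lasts longer. Compound 1 stands within the scatter of both neighbours: a 1.0-fold lower number from compound 1 to compound 2 (0.01 log units; within the scatter) and a 1.1-fold lower number from compound 1 to compound 3 (0.04 log units; within the scatter), and the two neighbours in turn sit within the scatter of each other, a 1.1-fold lower number from compound 2 to compound 3 (0.03 log units; within the scatter). Nothing among the three separates one from another.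

Compound 4, `CC(C)(C)C1=C(C(=O)O)N2C(=O)[C@H]([C@H](O)c3ccccc3)[C@@H]2O1`, is the next candidate. Relative to compound 1, (the two compounds have the same atoms and bonds and differ only in configuration as drawn: 1 of 3 stereo elements differ; a stereocentre at a saturated ring carbon is drawn R in compound 1 and S in compound 4). The three measured steps all swap the aryl group on the hydroxyl-bearing chain carbon and leave every stereocentre untouched, so none of them speaks to an inversion at a saturated ring carbon. They show only that this assay has so far been indifferent to the changes made; they give no direction for the change at hand. Going by the values given here, with no bearing step, the expectation for compound 4 defaults to compound 1 as the anchor, with a wide band on either side, and the expected step of a 1.1-fold lower number from compound 1 to compound 4 (0.03 log units; within the scatter) is one of no change beyond the scatter. Compound 4 is therefore estimated at 6.5 h, in the range 2.5 h to 14 h.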

Compound 4, half-life: 0.5 h
Compound 4: middle estimate off by 13-fold (1.11 log units), on the high side; measured number below the stated range.
By their numbers in this assay, from the lowest: compound 4; then compounds 3, 2 and 1 (each within the scatter of the next).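

In this assay, the saturated ring carbon proves to be a sensitive position, whereas the earlier swaps of the group on the saturated chain carbon moved nothing beyond the scatter. Turning this one stereocentre from R to S gives a 14-fold lower number from compound 1 to compound 4 (1.15 log units; beyond the scatter), so the configuration at this carbon counts for far more here than any of the group changes seen among compound 1, compound 2 and compound 3. The step can be laid on this single centre alone because nothing else separates the pair: the fact that compounds 1 and 4 differ only in the configuration as drawn

From the compounds shown here alone, whether the S configuration at this carbon shortens the half-life to the same extent with pyridin-4-yl or 1-methyl-1H-1,2,3-triazol-4-yl in place of phenyl stays open, as does the effect of inverting either of the other two stereo elements. Also open, going by these compounds, is whether an amine in place of phenyl on the saturated chain carbon would leave the number in this assay as unmoved as the earlier swaps did, with either configuration at the ring carbon.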